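The source may hold more compounds than are shown below. What is called first, only, known or untested is meant among the compounds shown, and "the series" means these compounds.

Measured compounds in an assay on isolated protein for binding affinity to adenosine receptor A1 (Bos taurus); on this read-out lower numbers stand for stronger inhibition and higher numbers for weaker inhibition:
Compound 1 `CNc1nc(-c2ccccc2)nc2c1nnn2Cc1ccccc1Cl` gives 191000000 nM.
Compound 2 `CCNc1nc(-c2ccccc2)nc2c1nnn2Cc1ccccc1Cl` gives 463000000 nM.
Compound 3 `CCCCCCNc1nc(-c2ccccc2)nc2c1nnn2Cc1ccccc1Cl` gives 31000000 nM.

Among these three, compound 1 holds the second highest number: its nearest neighbour is compound 2, with a 2.4-fold higher number from compound 1 to compound 2 (0.38 log units; beyond the scatter), and its furthest is compound 3, with a 6.2-fold lower number from compound 1 to compound 3 (0.79 log units; beyond the scatter). Compound 4 `CNc1nc(-c2ccccc2)nc2c1nnn2Cc1ccccc1` differs from compound 1 in one place: hydrogen in place of chloro on an aromatic carbon. Among the measured compounds shown here, none of the measured steps touches this place; all three, including a 15-fold lower number from compound 2 to compound 3 (1.17 log units; beyond the scatter), alter the chain on the nitrogen of the aromatic ring while the chloro group stays, so they carry no information on its removal. In this assay compound 4 is therefore expected to stay within the scatter of compound 1, with a 1.3-fold higher number from compound 1 to compound 4 (0.12 log units; within the scatter) as the expected step. The estimate for compound 4 is 250000000 nM, with a range from 80000000 nM to 800000000 nM.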

Compound 4, inhibition constant: 353000000 nM
For compound 4 the middle estimate is 1.4-fold (0.15 log units) below the measured one, and the stated range covers the measured number.
By their numbers in this assay, from the lowest: compound 3; then compounds 1, 4 and 2 (each within the scatter of the next, the first and the last beyond it).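

In this assay, among the compounds shown here, the change from 2-chlorobenzyl to benzyl gives a 1.8-fold higher number from compound 1 to compound 4 (0.27 log units; within the scatter) and is the first measured change at this aromatic carbon. With the chain on the nitrogen held as in compound 1, losing the chloro group therefore leaves the number within the scatter, unlike the steps along that chain. No available evidence accounts for this result. Open, as far as these compounds go, is how a fluoro or methoxy group would behave on this carbon. Also open, from the compounds shown here alone, is whether removing chloro would give a similar step with the longer chain of compound 3.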